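This account rests on a few compounds, and the source may have more. Where it says the series, first, only, none or still open, it means among the compounds named here.

Compound 3 `CCCN(Cc1cccs1)C(=O)COc1ccc(C)cc1`: 40 nM
Compound 1 `Cc1ccc(OCC(=O)N(Cc2cccs2)c2ccn(C)n2)cc1`: 855 nM
Compound 2 `Cc1ccc(OCC(=O)N(Cc2cccs2)c2nccn2C)cc1`: 1790 nM

Within the data shown here, of the three numbers measured in an assay on HEK293 cells for agonist activity at transient receptor potential cation channel subfamily M member 8 (Homo sapiens), read by fluorescence and calcium flux, with a stated time of 15 min (a higher number here means that more compound is needed for the effect, a lower number that less compound is needed), compound 3 stands lowest, the only member carrying propyl rather than a heterocycle on the amide-type nitrogen. The two steps that replace 1-methyl-1H-pyrazol-3-yl or 1-methyl-1H-imidazol-2-yl with propyl are both large: a 21-fold lower number from compound 1 to compound 3 (1.33 log units; beyond the scatter) and a 45-fold lower number from compound 2 to compound 3 (1.65 log units; beyond the scatter). Between the two heterocycles themselves the step is modest, a 2.1-fold higher number from compound 1 to compound 2 (0.32 log units; beyond the scatter). Compound 4 `Cc1ccc(OCC(=O)N(Cc2cccs2)c2cnccn2)cc1` introduces a third heterocycle at the same place: pyrazin-2-yl in place of propyl on an amide-type nitrogen. Because a 21-fold lower number from compound 1 to compound 3 (1.33 log units; beyond the scatter) and a 45-fold lower number from compound 2 to compound 3 (1.65 log units; beyond the scatter) both ran far in one direction, a large step upward is expected here as well, a 25-fold higher number from compound 3 to compound 4 (1.40 log units; beyond the scatter). Compound 4 is estimated at 1000 nM, with a likely range from 300 nM to 4000 nM.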

Compound 4, half-maximal effective concentration: 1240 nM
The estimate for compound 4 lay 1.2-fold (0.09 log units) below the measured number; the range from low to high includes it.
By their numbers in this assay, from the lowest: compound 3; then compounds 1, 4 and 2 (each within the scatter of the next, the first and the last beyond it).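

In this assay, pyrazin-2-yl on the amide-type nitrogen gives the same large rise as the two methylated heterocycles (a 31-fold higher number from compound 3 to compound 4 (1.49 log units; beyond the scatter)), so this rise also appears with a six-membered aromatic ring that carries no methyl group. Compound 4 cannot be separated from either earlier heterocycle (a 1.4-fold lower number from compound 2 to compound 4 (0.16 log units; within the scatter); a 1.5-fold higher number from compound 1 to compound 4 (0.16 log units; within the scatter)). At this position, all three heterocycles therefore stand well apart from propyl, while ring type and the methyl group leave compound 4 unresolved from the other two. On these data alone, whether butyl or cyclopentyl keeps the low number of compound 3 remains open. No measured evidence accounts for the gap between propyl and the heterocycles.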